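Hydroxy for Methylsulfanyl on a Core Without Readable Potency

The source may hold more compounds than are shown below. What is called first, only, known or untested is meant among the compounds shown, and "the series" means these compounds.

Measured compounds:
compound 1, `CCCc1nc(C)c2c(CC)nnc(SC)n12`: in a functional assay for inhibition, with Homo sapiens as the target (a higher number here means a weaker inhibitor, a lower number a stronger inhibitor), compound 1 gives > 48000 nM, a limit of the assay.
compound 2, `CCCc1nc(C)c2c(-c3ccccc3)nnc(SC)n12`: in this assay compound 2 gives > 48000 nM, again a limit.
compound 3, `CCCc1nc(C)c2cnnc(SC)n12`: in this assay compound 3 gives > 48000 nM, also a limit.

Compound 1 stands at the limit, and so do the other two compounds shown, as recorded in the limit of > 48000 nM in this assay, at which 3 of the 3 values shown sit. The steps among them, a step that the two limits leave unreadable from compound 1 to compound 2, a step that the two limits leave unreadable from compound 1 to compound 3 and a step that the two limits leave unreadable from compound 2 to compound 3, are therefore unreadable: all three concern the group on the aromatic carbon that carries ethyl in compound 1, and none of them concerns the methylsulfanyl group.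

Compound 4, `CCCc1nc(C)c2c(CC)nnc(O)n12`, differs from compound 1 in one place: hydroxy in place of methylsulfanyl on an aromatic carbon. Within the data shown here, no measured step touches this position, so nothing among the recorded values points to a direction or a size for the change in this assay. Compound 1 itself sits at the limit, leaving no number from which a step could be read.

Compound 4 is accordingly expected to remain at or around the limit, with an estimate of 60000 nM and a range from 20000 nM to 200000 nM. The expected step that the limit leaves unreadable from compound 1 to compound 4 is estimated as none beyond the scatter, with a further limit the most probable outcome.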

Compound 4, half-maximal inhibitory concentration: 15600 nM
The estimate for compound 4 lay 3.8-fold (0.59 log units) above the measured number; the whole stated range lies above it.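

In this assay, hydroxy in place of methylsulfanyl gives an at least 3.0-fold lower number from compound 1 to compound 4 (0.48 log units; beyond the scatter), while the steps among compound 1, compound 2 and compound 3 cannot be read. The aromatic carbon between two ring nitrogen atoms is thus a place where a single change on the core of compound 1 brings a measurable value, which the changes to the group on the other aromatic carbon could not show, as all of them ended at a limit. The step is only a lower bound on the true size, and it may be larger, because the starting value of compound 1 is a limit rather than a number: the limit of > 48000 nM in this assay, at which 3 of the 4 values shown sit.

The compounds shown leave open whether the step depends on hydroxy itself or would also appear with another small group on this carbon, such as methoxy or an amine. Among these compounds, they also leave open whether hydroxy would give a readable value with phenyl or hydrogen in place of the ethyl group para to it, since this change is seen only on the core of compound 1.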